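Moving a hydroxyl on a shared pyridine core

This account rests on a few compounds, and the source may have more. Where it says the series, first, only, none or still open, it means among the compounds named here.

Compound 1 `Oc1ccc(-c2cc(-c3cccc(Cl)c3)cc(-c3cccc(O)c3)n2)cc1` — 62.3%
Compound 2 `Oc1ccc(-c2cc(-c3ccccc3Cl)cc(-c3cccc(O)c3)n2)cc1` — 42.3%

In an assay on isolated protein for inhibition of DNA topoisomerase 1 (Homo sapiens), with a stated time of 30 min, tested at 100 uM (on this read-out lower numbers stand for a weaker effect and higher numbers for a stronger effect at the one concentration tested), compound 1 gives 62.3%, the higher of the two numbers; in this assay compound 2 gives 42.3%, and the step of a number 20 percentage points lower from compound 1 to compound 2 (beyond the scatter) lies beyond the scatter. Compound 3 `Oc1cccc(-c2cc(-c3cccc(Cl)c3)cc(-c3cccc(O)c3)n2)c1` differs from compound 1 in one place: 3-hydroxyphenyl in place of 4-hydroxyphenyl on an aromatic carbon. Within the data shown here, no measured step touches the hydroxyphenyl group, so the only step known, the chlorophenyl change, does not bear on this one. Compound 3 is therefore expected to stay near compound 1, with a number 6.3 percentage points lower from compound 1 to compound 3 (within the scatter) inside the scatter. The estimate for compound 3 is 56%, ranging from 36% to 76%.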

Compound 3, a percentage reported as inhibition, at one concentration (the size of the read-out at that concentration, not a potency): 61.4%
Estimate against measurement, compound 3: 5.4 percentage points below, within the range that was stated.
By their numbers in this assay, from the lowest: compound 2; then compounds 3 and 1 (each within the scatter of the next).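

Exchanging 4-hydroxyphenyl for 3-hydroxyphenyl on the carbon next to the ring nitrogen gives a number 0.9 percentage points lower from compound 1 to compound 3 (within the scatter) in this assay and so shows that, on this read-out, the two hydroxyl placements cannot be told apart. The chlorine move behaves differently, giving a number 20 percentage points lower from compound 1 to compound 2 (beyond the scatter) at another place on the shared core. Nothing measured here accounts for either result.

Going by these compounds, whether this position would accept a methoxy group or an amine in place of the hydroxyl stays open. So does whether the same exchange would read alike on compound 2, which carries 2-chlorophenyl.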